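The source may hold more compounds than are shown below. What is called first, only, known or untested is meant among the compounds shown, and "the series" means these compounds.

The account follows a small series tested in a functional assay on MCF7 cells (Homo sapiens) for antiproliferative activity, read by MTT assay, with a stated time of 24 h; a higher number here means a weaker inhibitor, a lower number a stronger inhibitor. Compound 1 `Cc1ccc(-c2cn(C/C=C3\OC(=O)C(OCc4ccccc4)=C3OCc3ccccc3)nn2)cc1` gives only a limit there, > 100000 nM. Its place is therefore the top of what the measurements record, a limit that another compound also reaches (the limit of > 100000 nM in this assay, at which 2 of the 3 values shown sit). Compound 2 `COC1=C(OC)C(O)(CCn2cc(-c3ccc(C(C)(C)C)cc3)nn2)NC1=O`, built on a different core, likewise gives only a limit, > 100000 nM, in this assay. Compound 3 `COC1=C(OC)C(O)(CCn2cc(-c3ccccc3)nn2)NC1=O` carries hydrogen in place of tert-butyl on an aromatic carbon relative to compound 2. Within the data shown here, of the three, compound 3 is the one with a number, 22600 nM. Among the measured compounds shown here, the only measured step is an at least 4.4-fold lower number from compound 2 to compound 3 (0.64 log units; beyond the scatter), a trimming of a group on an aromatic carbon rather than an exchange of the ring itself.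

Compound 4 `O=C1O/C(=C\Cn2cc(-c3ccccn3)nn2)C(OCc2ccccc2)=C1OCc1ccccc1` differs from compound 1 by pyridin-2-yl in place of 4-methylphenyl on an aromatic carbon. For the measured compounds named here, the step from compound 2 to compound 3 is the only guide: it concerns another core and another kind of change, so it bears on the present step only loosely. A modest move toward a lower number is expected, an at least 1.6-fold lower number from compound 1 to compound 4 (0.22 log units; that floor lies within the scatter), with the figure possibly still sitting at the limit. Compound 4 is expected to give about 60000 nM, between 15000 nM and 150000 nM.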

Compound 4, half-maximal inhibitory concentration: > 100000 nM
Compound 4: a limit, no number; the forecaster's own chance of this, stated with the estimate: 50%; middle value at least 1.6-fold (0.22 log units) away from the limit.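

In this assay compound 4 gives only a limit of > 100000 nM. Compound 1 also gives only a limit, so the step between compound 1 and compound 4 cannot be read: the limit of > 100000 nM in this assay, at which 3 of the 4 values shown sit. The compounds shown leave open whether pyridin-2-yl in place of 4-methylphenyl on the shared core makes any difference in this assay.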